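Series notes: aryl replacement at the core of compound 1

This account rests on a few compounds, and the source may have more. Where it says the series, first, only, none or still open, it means among the compounds named here.

Compound 1 `Cn1nccc1-c1cnc(NCc2c(F)ccc3c2CCO3)c2cn[nH]c(=O)c12` is the reference point for the present comparison. In an ADME assay on microsomes from liver (Homo sapiens) for metabolic stability, read by LC-MS, using NADPH, with stated times of 5 min and 30 min, tested at 1 uM (a higher number here means faster removal of the compound, a lower number slower removal), compound 1 gives 14 mL.min-1.g-1, the lower of the two numbers in hand. Compound 2 `CN(c1ccccc1)c1cnc(NCc2c(F)ccc3c2CCO3)n2cnnc12`, which shares the fluoro-dihydrobenzofuranylmethylamine but carries a different bicyclic core and an N-methyl-N-phenylamine, gives 55 mL.min-1.g-1 in this assay; the gap from compound 1 to compound 2 lies beyond the scatter, so compound 1 is the more slowly removed of the two. Among the compounds with values here, no pair of measured compounds differing in a single place is available, so the change leading to compound 3 `CNC(=O)c1ccc(-c2cnc(NCc3c(F)ccc4c3CCO4)c3cn[nH]c(=O)c23)c(C)n1` has no measured precedent. The difference from compound 1 to compound 3 is 2-methyl-6-(methylcarbamoyl)pyridin-3-yl in place of 1-methyl-1H-pyrazol-5-yl on an aromatic carbon. Given only the value of compound 1 in this assay, compound 3 is expected to show no step beyond the scatter, with a 1.3-fold higher number from compound 1 to compound 3 (0.11 log units; within the scatter) as the expected change. The estimate for compound 3 in this assay is 18 mL.min-1.g-1, within a range from 7 mL.min-1.g-1 to 45 mL.min-1.g-1.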

Compound 3, intrinsic clearance in microsomes: 23 mL.min-1.g-1
Estimate against measurement, compound 3: 1.3-fold (0.11 log units) below; the measured number falls inside the stated range.
By their numbers in this assay, from the lowest: compounds 1 and 3 (each within the scatter of the next); then compound 2.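

In this assay, 2-methyl-6-(methylcarbamoyl)pyridin-3-yl in place of 1-methyl-1H-pyrazol-5-yl on this aromatic carbon gives a 1.6-fold higher number from compound 1 to compound 3 (0.22 log units; within the scatter). Within the data shown here, this is the first single-place change, and it shows that this position accepts a six-membered aromatic ring of 11 heavy atoms, carrying a hydrogen-bond donor, with no step beyond the scatter in this read-out. Nothing shown accounts for this outcome.

The contributions of the 2-methyl group, the methylcarbamoyl group and the pyridine ring itself remain unseparated at this position. Also open, going by these compounds, is whether the same holds for other groups on this carbon, such as a carboxylic acid in place of the methylcarbamoyl group or an amine on the pyridine ring.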